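Hydroxyethyl for cyclopropyl on the amine of the shared core

The source may hold more compounds than are shown below. What is called first, only, known or untested is meant among the compounds shown, and "the series" means these compounds.

Among the compounds with values here, compound 2 `Clc1ccccc1Cn1nnc2c(NC3CC3)nc(-c3ccccc3)nc21` gives 11 nM in an assay on Cerebral cortex for displacement of a labelled ligand from adenosine receptor A1 (Bos taurus) (a higher number here means a weaker inhibitor, a lower number a stronger inhibitor), the lowest of the two numbers so far. Within the data shown here, compound 1 `CNc1nc(-c2ccccc2)nc2c1nnn2Cc1ccccc1Cl` gives 191 nM in this assay, and the single step, a 17-fold lower number from compound 1 to compound 2 (1.24 log units; beyond the scatter), is the only one that speaks to the nitrogen substituent. Compound 3 `OCCNc1nc(-c2ccccc2)nc2c1nnn2Cc1ccccc1Cl` carries the change 2-hydroxyethyl in place of cyclopropyl on a nitrogen on an aromatic ring at that same nitrogen. Among the measured compounds shown here, no measured step covers a 2-hydroxyethyl group, so the expectation is a step of a 9.1-fold higher number from compound 2 to compound 3 (0.96 log units; beyond the scatter), going back toward the number of compound 1. Compound 3 is estimated at 100 nM, with a range from 25 nM to 400 nM.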

Compound 3, inhibition constant: 116 nM
Compound 3: the middle estimate sits 1.2-fold (0.06 log units) below what was measured; measured number inside the range.
By their numbers in this assay, from the lowest: compound 2; then compounds 3 and 1 (each within the scatter of the next).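

Swapping the ring for an open chain at this nitrogen costs most of what cyclopropyl gained (an 11-fold higher number from compound 2 to compound 3 (1.02 log units; beyond the scatter)), so in this assay the low number of compound 2 is not kept by a 2-hydroxyethyl group of the same heavy-atom count. Hydroxymethyl in place of hydrogen on the methyl group of compound 1 gives a step within the scatter (a 1.6-fold lower number from compound 1 to compound 3 (0.22 log units; within the scatter)), so compounds 1 and 3 cannot be told apart here. No measurement is available to explain either step.

The step from compound 2 to compound 3 removes the ring and brings in the oxygen together, so the two cannot be separated. A propyl chain or a cyclobutyl ring at this nitrogen lies outside the compounds shown.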